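Swapping vinyl for 2-(ethoxycarbonyl)ethyl on a carbonyl carbon

The source may report more compounds than this note shows. Statements on the series, on what has been measured and on what is new or still open speak of the compounds shown alone.

Measured in a functional assay on the whole organism for inhibition, with Cavia porcellus as the target; on this read-out higher numbers stand for an effect only at larger amounts of compound and lower numbers for an effect already at smaller amounts:
compound 1 `COc1ccccc1OCC1SCCN1C(=O)Cn1ccnc1`: 50 mg/kg
compound 2 `COc1ccccc1OCC1SCCN1C(C)=O`: 46 mg/kg
compound 3 `C=CC(=O)N1CCSC1COc1ccccc1OC`: 74 mg/kg

Compound 3 stands at 74 mg/kg, within the scatter of both other compounds, so no order can be read among the three. The next compound to be tested is compound 4 `CCOC(=O)CCC(=O)N1CCSC1COc1ccccc1OC`, which has 2-(ethoxycarbonyl)ethyl in place of vinyl on a carbonyl carbon.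

Going by the values given here, three measured steps bear on this change, since each alters the group on that same carbonyl carbon. Vinyl in place of methyl gave a 1.6-fold higher number from compound 2 to compound 3 (0.21 log units; within the scatter). Vinyl in place of (1H-imidazol-1-yl)methyl gave a 1.5-fold higher number from compound 1 to compound 3 (0.17 log units; within the scatter). The remaining exchange gave a 1.1-fold lower number from compound 1 to compound 2 (0.04 log units; within the scatter). None of these steps leaves the scatter, so no step beyond the scatter is expected in this assay, and no direction can be argued with confidence. Among the compounds with values here, no measured compound carries 2-(ethoxycarbonyl)ethyl, however, so the expected range is kept wide.

The expected change is a 1.3-fold lower number from compound 3 to compound 4 (0.13 log units; within the scatter).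

For compound 4 the estimated value is 55 mg/kg, with an expected range from 25 mg/kg to 120 mg/kg.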

Compound 4, dose for half-maximal effect: 24 mg/kg
Compound 4: the middle estimate sits 2.3-fold (0.36 log units) above what was measured; the whole stated range lies above it.
By their numbers in this assay, from the lowest: compounds 4, 2, 1 and 3 (each within the scatter of the next, the first and the last beyond it).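

In this assay, going by these compounds alone, the group on this carbonyl carbon now produces a difference beyond the scatter, which no step among the first three compounds did: 2-(ethoxycarbonyl)ethyl in place of vinyl gives a 3.1-fold lower number from compound 3 to compound 4 (0.49 log units; beyond the scatter), and (ethoxycarbonyl)methyl in place of 1H-imidazol-1-yl on the saturated chain carbon gives a 2.1-fold lower number from compound 1 to compound 4 (0.32 log units; beyond the scatter); both steps are modest. The comparison with the plain acetyl-type side chain does not separate in the same way, since (ethoxycarbonyl)methyl in place of hydrogen gives a 1.9-fold lower number from compound 2 to compound 4 (0.28 log units; within the scatter), so the ester-bearing chain stands clear of the vinyl and imidazolyl compounds but not of the smallest group shown. Nothing measured here accounts for these steps.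

The compounds shown leave open whether the ester or the chain itself goes with the lower number, since no compound separates the two; a carboxylic acid in place of the ethyl ester, or a plain butyl chain on the same carbonyl carbon, would bear on that. Going by these compounds, it also remains open how a longer chain ending in the same ester, or one ending in an amine, would read in this assay.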